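Hydroxy in place of bromo on a series at the limit

This account rests on a few compounds, and the source may have more. Where it says the series, first, only, none or still open, it means among the compounds named here.

compound 1 `Fc1cccc(-c2nc(Nc3cccc(Cl)c3)c3cc(F)ccc3n2)c1` reaches in a functional assay on U-937 cells (Homo sapiens) for cytotoxicity, read by MTT assay, with a stated time of 48 h (on this read-out lower numbers stand for stronger inhibition and higher numbers for weaker inhibition), only a limit, > 50000 nM.
compound 2 `Fc1cccc(-c2nc(Nc3cccc(Br)c3)c3cc(F)ccc3n2)c1` reaches in this assay only a limit, > 50000 nM.
compound 3 `Fc1cccc(-c2nc(Nc3ccccc3Br)c3cc(F)ccc3n2)c1` reaches in this assay only a limit, > 50000 nM.

Compound 3 thus stands at the limit, and every value shown sits there (the limit of > 50000 nM in this assay, at which 3 of the 3 values shown sit). The steps a step that the two limits leave unreadable from compound 1 to compound 3 and a step that the two limits leave unreadable from compound 2 to compound 3, as well as a step that the two limits leave unreadable from compound 1 to compound 2, cannot be sized. Compound 4 `Oc1ccccc1Nc1nc(-c2cccc(F)c2)nc2ccc(F)cc12` differs from compound 3 by hydroxy in place of bromo on an aromatic carbon. Among the measured compounds shown here, no measured step bears on this change with a readable size, so the expectation rests on compound 3 alone. Compound 4 is therefore expected to stay at a weak level, with an estimated step of a number no higher from compound 3 to compound 4 (the limit leaves the size open). For compound 4 the estimate is 50000 nM, ranging from 10000 nM to 200000 nM.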

Compound 4, half-maximal inhibitory concentration: 46300 nM
Beside the measured number, compound 4's estimate is 1.1-fold (0.03 log units) above it, and the stated range covers the measured number.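

In this assay, with hydroxy where compound 3 carries bromo, compound 4 gives a real number, 46300 nM, the only one in the series shown that is not a limit. Among the compounds shown here, the steps read an at least 1.0-fold lower number from compound 3 to compound 4 (0.03 log units; that floor lies within the scatter), an at least 1.0-fold lower number from compound 2 to compound 4 (0.03 log units; that floor lies within the scatter) and an at least 1.0-fold lower number from compound 1 to compound 4 (0.03 log units; that floor lies within the scatter), so no gain beyond the scatter can be claimed, and the remaining steps among the earlier compounds cannot be read. The other compounds all remain at a limit: the limit of > 50000 nM in this assay, at which 3 of the 4 values shown sit.

On these data alone, how far compound 4 truly lies from compound 3 stays open. So does whether an amine or a methoxy group on that aromatic carbon would also give a readable number.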